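The source may hold more compounds than are shown below. What is called first, only, known or untested is meant among the compounds shown, and "the series" means these compounds.

Measured so far in a functional assay on PC-3 cells (Homo sapiens) for inhibition, read by MTT assay, with a stated time of 72 h; on this read-out lower numbers stand for stronger inhibition and higher numbers for weaker inhibition:
compound 1 `O=C(CSc1nc(Nc2ccccc2)c2ccccc2n1)Nc1ccccc1F`, 12400 nM
compound 2 `O=C(CSc1nc(Nc2ccccc2)c2ccccc2n1)Nc1ccccc1Cl`, 14600 nM
compound 3 `CCc1cccc(NC(=O)CSc2nc(Nc3ccccc3)c3ccccc3n2)c1`, 11000 nM

Of the three numbers, that of compound 3 is the lowest, but its gaps to compound 1 and compound 2 both lie within the scatter, so the three sit together. Compound 4 `O=C(CSc1nc(Nc2ccccc2)c2ccccc2n1)Nc1ccc(Br)cc1` is not yet measured; it differs from compound 3 by 4-bromophenyl in place of 3-ethylphenyl on an amide-type nitrogen. Two earlier steps altered the same aryl group on the amide-type nitrogen: a 1.1-fold lower number from compound 1 to compound 3 (0.05 log units; within the scatter) and a 1.3-fold lower number from compound 2 to compound 3 (0.12 log units; within the scatter); a halogen swap on that ring gave a 1.2-fold higher number from compound 1 to compound 2 (0.07 log units; within the scatter). None moved beyond the scatter. For compound 4 the expected step in this assay is therefore a 1.2-fold higher number from compound 3 to compound 4 (0.07 log units; within the scatter), none beyond the scatter. Compound 4 is estimated at 13000 nM, with a range of 5000 nM to 35000 nM.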

Compound 4, half-maximal inhibitory concentration: 8450 nM
Beside the measured number, compound 4's estimate is 1.5-fold (0.19 log units) above it; the measured number falls inside the stated range.
By their numbers in this assay, from the lowest: compounds 4, 3, 1 and 2 (each within the scatter of the next).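

In this assay, 4-bromophenyl on the amide-type nitrogen stays within the scatter of all three earlier aryl groups (a 1.3-fold lower number from compound 3 to compound 4 (0.11 log units; within the scatter); a 1.7-fold lower number from compound 2 to compound 4 (0.24 log units; within the scatter); a 1.5-fold lower number from compound 1 to compound 4 (0.17 log units; within the scatter)). A bromine-bearing aryl group thus joins the fluoro, chloro and ethyl variants, and no step among these four compounds lies beyond the scatter. No available evidence bears on this result.

As far as these compounds go, whether any change at this nitrogen can move the number remains open, for example a ring carrying an amine or a carboxylic acid, or a longer chain in place of the aryl group. From the compounds shown here alone, the rest of the molecule is the same in all four compounds, so its contribution also remains open.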